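A few compounds are considered here, and "the series" means these few. Any claim that something is new, unique, unknown or untested is made for them only; others in the source may bear on it.

Two compounds have results so far in a functional assay on HeLa cells (Homo sapiens) for inhibition, read by MTT assay, with a stated time of 72 h (a higher number here means a weaker inhibitor, a lower number a stronger inhibitor), and they differ in several places. Compound 1 (`COc1cc(/C=C/C(=O)c2c(OC)cc(O)c(CC=C(C)C)c2O)ccc1O`) gives 33800 nM as a true number. Compound 2 (`COc1cc(O)cc(O)c1C(=O)/C=C/c1ccc(C)cc1`) reads > 50000 nM and that value is a limit of the assay, not a number. So compound 2 offers a boundary rather than a fixed point to start from.

Compound 3 (`COc1cc(O)cc(O)c1C(=O)/C=C/c1ccc(C(F)(F)F)cc1`) keeps the rest of compound 2 unchanged and carries trifluoromethyl in place of methyl on an aromatic carbon, para to a large group (trifluoromethyl in place of methyl on an aromatic carbon). Within the data shown here, no pair of measured compounds shows what a change at this place does, so the data offer no guide to its size or direction. The modest expectation is therefore no step beyond the usual scatter of repeated measurements. In numbers, the expected step is an at least 1.1-fold lower number from compound 2 to compound 3 (0.04 log units; that floor lies within the scatter) and it remains only an estimate. For compound 3 the estimated half-maximal inhibitory concentration is 20000 nM to 80000 nM around a middle of 45000 nM and the assay may well report only a limit again.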

Compound 3, half-maximal inhibitory concentration: 9500 nM
Estimate against measurement, compound 3: 4.7-fold (0.68 log units) above, and the stated range ends above it.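

In this assay, among these compounds, the swap of methyl for trifluoromethyl on the aromatic carbon, para to a large group, is the first change in this set that can be followed at a single place, and it brings an at least 5.2-fold lower number from compound 2 to compound 3 (0.72 log units; beyond the scatter). This shows that the position is not indifferent: what sits there can move the number beyond the usual scatter, and the direction of this change is towards a stronger inhibitor. The true size of the step stays unknown, and the step can only be given as a floor, because compound 2 has no fixed value to measure from, only a limit of the assay: the limit of > 50000 nM in this assay, at which 1 of the 3 values shown sits.

This is one pair and one swap, so it cannot say whether other groups at this place, such as a chlorine atom, a nitrile or an amine, would move the number in the same direction or further. Nor can it say whether the same swap would act alike on the core of compound 1, which differs from compound 2 in several places.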